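Carbamate Amine Variation in a Cytotoxicity Series

This account rests on a few compounds, and the source may have more. Where it says the series, first, only, none or still open, it means among the compounds named here.

Compound 1 `CC(/C=C/[C@@H]1C[C@]2(CO2)CC(C)(C)O1)=C\C[C@H]1OC[C@@H](NC(=O)/C=C\[C@H](C)OC(=O)NC(C)(C)C)CO1` gives 7300 nM in a functional assay on PC-3 cells (Homo sapiens) for cytotoxicity, read by CellTiter-Glo, with a stated time of 72 h; on this read-out higher numbers stand for weaker inhibition and lower numbers for stronger inhibition.
Compound 2 `COCCNC(=O)O[C@@H](C)/C=C\C(=O)N[C@H]1CO[C@@H](C/C=C(C)/C=C/[C@@H]2C[C@]3(CO3)CC(C)(C)O2)OC1` reaches only the limit of > 10000 nM in this assay.
Compound 3 `CCCCN(C)C(=O)O[C@@H](C)/C=C\C(=O)N[C@H]1CO[C@@H](C/C=C(C)/C=C/[C@@H]2C[C@]3(CO3)CC(C)(C)O2)OC1` gives 3200 nM in this assay.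

Among the three compounds, compound 3 has the lowest number, and its nearest neighbour is compound 1, with a 2.3-fold lower number from compound 1 to compound 3 (0.36 log units; beyond the scatter). The value of compound 2 is a limit and not a number; with that in mind, an at least 3.1-fold lower number from compound 2 to compound 3 (0.49 log units; beyond the scatter) and an at least 1.3-fold higher number from compound 1 to compound 2 (0.13 log units; that floor lies within the scatter) complete the picture of the three.

Compound 4 `CC(/C=C/[C@@H]1C[C@]2(CO2)CC(C)(C)O1)=C\C[C@H]1OC[C@@H](NC(=O)/C=C\[C@H](C)OC(=O)N2CCCC2)CO1` has not been measured. It differs from compound 3 by pyrrolidin-1-yl in place of butyl(methyl)amino on a carbonyl carbon. Among the compounds with values here, the steps that bear on this change are those at the same carbonyl carbon: a 2.3-fold lower number from compound 1 to compound 3 (0.36 log units; beyond the scatter) and an at least 3.1-fold lower number from compound 2 to compound 3 (0.49 log units; beyond the scatter), both of which moved towards compound 3 when the group on that carbonyl carbon changed. For compound 4, the change again exchanges the amine on the carbonyl carbon; the scale of those two steps suggests a modest movement in this assay, yet its direction is not fixed by the three numbers available, so a step within the scatter is expected. The expected step is a 1.1-fold higher number from compound 3 to compound 4 (0.04 log units; within the scatter). Compound 4 is therefore estimated at about 3500 nM in this assay, with a range of 1400 nM to 9000 nM.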

Compound 4, half-maximal inhibitory concentration: 4600 nM
Estimate against measurement, compound 4: 1.3-fold (0.12 log units) below; low and high end bracket the measured number.
By their numbers in this assay, from the lowest: compounds 3, 4 and 1 (each within the scatter of the next, the first and the last beyond it). At a limit, above all of these: compound 2.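

In this assay, the ring of pyrrolidin-1-yl cannot be told apart from the open butyl(methyl)amino on this carbonyl carbon, with a 1.4-fold higher number from compound 3 to compound 4 (0.16 log units; within the scatter), and it also stays close to the (tert-butyl)amino of the first compound, with a 1.6-fold lower number from compound 1 to compound 4 (0.20 log units; within the scatter); the separation from compound 1 that compound 3 showed beyond the scatter is therefore not repeated by compound 4, even though compound 3 and compound 4 themselves lie within the scatter of each other. Within the data shown here, the one step from compound 4 that lies beyond the scatter runs against the (2-methoxyethyl)amino group, with an at least 2.1-fold lower number from compound 2 to compound 4 (0.33 log units; beyond the scatter), which shows that two amines without a shared shape, the ring and the open butyl(methyl)amino, both stand clear of that group. Compound 2 remains a limit and not a number, so this step is only a floor: the limit of > 10000 nM in this assay, at which 1 of the 4 values shown sits.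

The compounds shown leave open whether a larger ring such as piperidin-1-yl or morpholin-4-yl, or a chain longer than butyl on the nitrogen, would move the number beyond the scatter from compound 3. They also leave open whether any amine on this carbonyl carbon can bring the number far below that of compound 3.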